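Isopropoxy in place of chloro: working notes on cytotoxicity

The source may report more compounds than this note shows. Statements on the series, on what has been measured and on what is new or still open speak of the compounds shown alone.

Measured in an ADME assay on HEp-2 cells (Homo sapiens) for cytotoxicity, read by MTT assay, with a stated time of 72 h; on this read-out lower numbers stand for stronger inhibition and higher numbers for weaker inhibition:
- compound 1 `COc1ccc(C2=C(c3cc(OC)c(OC)c(OC)c3)C(=O)C(OC(C)=O)C2)cc1OC(C)C`: > 100 ug/mL
- compound 2 `COc1ccc(C2=C(c3cc(OC)c(OC)c(OC)c3)C(=O)C(O)C2)cc1NC(=O)c1ccccc1`: > 100 ug/mL
- compound 3 `COc1ccc(C2=C(c3cc(OC)c(OC)c(OC)c3)C(=O)C(O)C2)cc1Cl`: < 1 ug/mL

All three entries are limits of the assay and not numbers. Compound 3 stands at the limit of < 1 ug/mL in this assay, at which 1 of the 3 values shown sits, and no other compound shown shares that limit. Compound 1 and compound 2 stand at the limit of > 100 ug/mL in this assay, at which 2 of the 3 values shown sit.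

Compound 4 `COc1ccc(C2=C(c3cc(OC)c(OC)c(OC)c3)C(=O)C(O)C2)cc1OC(C)C` differs from compound 3 at one place: isopropoxy in place of chloro on an aromatic carbon. The measured step that bears most directly on this change is an at least 100-fold lower number from compound 2 to compound 3 (2.00 log units; beyond the scatter), a large step at the same aromatic carbon. It shows that a change at this carbon can shift the result in this assay strongly. Compound 1 also carries the isopropoxy group and sits at the upper limit, but it differs from compound 4 at a further place, so it is only a weak pointer.

A move to a higher number, meaning weaker inhibition, is therefore expected, probably beyond the scatter but smaller than the measured step. The expected size is an at least 10-fold higher number from compound 3 to compound 4 (1.00 log units; beyond the scatter), and the uncertainty is wide. For compound 4 the estimate is 10 ug/mL, with an expected range from 0.7 ug/mL to 100 ug/mL.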

Compound 4, half-maximal inhibitory concentration: > 100 ug/mL
Compound 4: no number, only a limit (the forecaster's own chance of this, stated with the estimate: 45%); middle value at least 10-fold (1.00 log units) away from the limit.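

In this assay, isopropoxy in place of chloro on this aromatic carbon, ortho to a methoxy group, gives an at least 100-fold higher number from compound 3 to compound 4 (2.00 log units; beyond the scatter), so this single change is enough to separate the two ends of the range shown. Compound 1 could not show this, as it carries an acetyl on the oxygen on a saturated carbon as well as the isopropoxy group, whereas here the isopropoxy group meets the upper limit with that oxygen bearing hydrogen. Compound 4 gives a limit and not a number, so the printed step marks only the smallest size the data allow: the limit of > 100 ug/mL in this assay, at which 3 of the 4 values shown sit.

From the compounds shown here alone, the steps to compound 4 from compound 1 and from compound 2 cannot be read, so the effect of the acetyl and any order between isopropoxy and benzamido remain unknown. Compound 3 also gives a limit and not a number, and the compounds shown leave open whether chloro is unusual at this carbon or whether an amine, a fluoro or an ethoxy group there would also stay at the lower end: the limit of < 1 ug/mL in this assay, at which 1 of the 4 values shown sits.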